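Ring amide replaces carbamate chain on the shared core

The source may report more compounds than this note shows. Statements on the series, on what has been measured and on what is new or still open speak of the compounds shown alone.

Of the compounds shown here, three built on a shared core have been measured in a functional assay on PC-3 cells (Homo sapiens) for antiproliferative activity, read by MTT assay, with a stated time of 72 h; on this read-out lower numbers stand for stronger inhibition and higher numbers for weaker inhibition. Compound 1 `CCCSc1nc(Cl)c2c(n1)N(Cc1ccccc1)C(C(=O)N1CCN(Cc3ccccc3)CC1)N2` gives 57300 nM, compound 2 `CCCSc1nc(Cl)c2c(n1)N(Cc1ccccc1)C(C(=O)O)N2` gives 49200 nM, and compound 3 `CCCSc1nc(Cl)c2c(n1)N(Cc1ccccc1)C(C(=O)NCCNC(=O)OC(C)(C)C)N2` gives 29700 nM. Compound 3 holds the lowest of the three numbers, yet the step of a 1.7-fold lower number from compound 2 to compound 3 (0.22 log units; within the scatter) lies within the scatter, and the values of compound 1 and compound 3 also sit within the scatter of each other, so no order among the three can be drawn.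

Compound 4 `CCCSc1nc(Cl)c2c(n1)N(Cc1ccccc1)C(C(=O)N1CCN(C)CC1)N2` differs from compound 3 by 4-methylpiperazin-1-yl in place of (2-((tert-butoxycarbonyl)amino)ethyl)amino on a carbonyl carbon. For the measured compounds named here, the only measured step that touches this carbonyl carbon, a 1.7-fold lower number from compound 2 to compound 3 (0.22 log units; within the scatter), was within the scatter, and the value of compound 1 shows that another amide at the same position stays close to compound 3. On that ground the step of a 1.3-fold higher number from compound 3 to compound 4 (0.13 log units; within the scatter) is expected to bring no shift beyond the scatter. The estimate for compound 4 in this assay is 40000 nM, with a range from 18000 nM to 90000 nM.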

Compound 4, half-maximal inhibitory concentration: 29800 nM
Compound 4: the middle estimate sits 1.3-fold (0.13 log units) above what was measured, within the range that was stated.
By their numbers in this assay, from the lowest: compounds 3, 4, 2 and 1 (each within the scatter of the next).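

In this assay, exchanging the open chain for the 4-methylpiperazin-1-yl ring on this carbonyl carbon, a smaller group with no hydrogen-bond donors, leaves the number unmoved: the result is a 1.0-fold higher number from compound 3 to compound 4 (0.00 log units; within the scatter). The two other comparisons, a 1.7-fold lower number from compound 2 to compound 4 (0.22 log units; within the scatter) and a 1.9-fold lower number from compound 1 to compound 4 (0.28 log units; within the scatter), also stay within the scatter, so neither replacing hydroxy with this ring nor hydrogen in place of phenyl on the saturated chain carbon gives a difference that can be read. No supporting evidence bears on these results.

No group shown at this carbonyl carbon moves the number beyond the scatter, so whether a primary amine or a longer chain ending in a carboxylic acid would do so remains open. The compounds shown also do not vary the rest of the shared core, so its part in these values is unknown.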